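The source may report more compounds than this note shows. Statements on the series, on what has been measured and on what is new or still open speak of the compounds shown alone.

Measured compounds:
compound 1, `COc1cc2c(Oc3ccc(NC(=O)c4nn(-c5ccccc5)c(=O)cc4C)cc3F)ccnc2cc1OCCCN1CCCCC1`, 1370 nM
compound 2, `COc1cc2c(Oc3ccc(NC(=O)c4nn(-c5ccccc5OC(F)(F)F)c(=O)cc4C)cc3F)ccnc2cc1OCCCN1CCCCC1`, 1300 nM

In a functional assay on U-87MG ATCC cells (Homo sapiens) for inhibition, read by MTT assay, with a stated time of 72 h (on this read-out higher numbers stand for weaker inhibition and lower numbers for stronger inhibition), compound 1 gives 1370 nM. In this assay compound 2 gives 1300 nM. The two numbers sit within the scatter of each other, so compound 2 cannot be set apart from compound 1 on this read-out.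

Compound 3, `COc1cc2c(Oc3ccc(NC(=O)c4nn(-c5cccc(F)c5)c(=O)cc4C)cc3F)ccnc2cc1OCCCN1CCCCC1`, is not yet measured. It differs from compound 2 in one place: 3-fluorophenyl in place of 2-(trifluoromethoxy)phenyl on an aromatic nitrogen. For the measured compounds named here, the only measured step bears on the same phenyl group: a 1.1-fold lower number from compound 1 to compound 2 (0.02 log units; within the scatter), where adding a trifluoromethoxy group changed nothing beyond the scatter. Going by the values given here, that step does not cover a fluorine on the phenyl ring, and no other measured pair covers it, so the basis is thin. On what is known, no step beyond the scatter is expected from compound 2 to compound 3, a 1.0-fold higher number from compound 2 to compound 3 (0.02 log units; within the scatter). Compound 3 is estimated at 1350 nM, with a range from 600 nM to 3000 nM.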

Compound 3, half-maximal inhibitory concentration: 1500 nM
Compound 3: middle estimate off by 1.1-fold (0.05 log units), on the low side; low and high end bracket the measured number.
By their numbers in this assay, from the lowest: compounds 2, 1 and 3 (each within the scatter of the next).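

In this assay, the ring on the aromatic nitrogen now also carries a fluorine: 3-fluorophenyl in place of 2-(trifluoromethoxy)phenyl gives a 1.2-fold higher number from compound 2 to compound 3 (0.06 log units; within the scatter) as the step, and fluoro in place of hydrogen on an aromatic carbon gives a 1.1-fold higher number from compound 1 to compound 3 (0.04 log units; within the scatter) as the step on this same ring. For the compounds shown here, the single earlier step covered only trifluoromethoxy, whereas the phenyl, 2-(trifluoromethoxy)phenyl and 3-fluorophenyl compounds now all sit within the scatter of one another on this read-out. No independent data bear on this result.

As far as these compounds go, whether an amine or a carboxylic acid on this phenyl ring would move the number beyond the scatter stays open. The same holds for a longer chain in place of the phenyl ring.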